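The source may hold more compounds than are shown below. What is called first, only, known or untested is meant among the compounds shown, and "the series" means these compounds.

Of the compounds shown here, two of one family have been measured. Compound 1 `CCOc1ccc(C(=O)Nc2cc(Br)cc3c(=O)cc(C(=O)O)oc23)cc1` is tested in an assay on CHO cells for agonist activity at G protein-coupled receptor GPR35 (Rattus norvegicus), read by a beta-galactosidase reporter and beta-arrestin recruitment, with a stated time of 90 min (a higher number here means that more compound is needed for the effect, a lower number that less compound is needed), and gives 1360 nM. Compound 2 `CCCOc1ccc(C(=O)Nc2cccc3c(=O)cc(C(=O)O)oc23)cc1` is the other measured member; in this assay compound 2 gives 3610 nM. Compound 1 thus stands at the lower of the two numbers, and the gap to compound 2 is wider than the usual scatter, so compound 1 needs less material for its effect than compound 2 does. The two differ in more than one place, so nothing can be pinned on a single change between them.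

Compound 3 `COc1ccccc1C(=O)Nc1cc(Br)cc2c(=O)cc(C(=O)O)oc12` has not been measured. It shares the core of compound 1 and differs from compound 1 by 2-methoxyphenyl in place of 4-ethoxyphenyl on a carbonyl carbon. Among the compounds with values here, no measured pair shows this kind of change, so the direction of its effect is open. The step from compound 1 to compound 3 is expected to be a 1.8-fold higher number from compound 1 to compound 3 (0.26 log units; within the scatter), a modest loss. For compound 3 the expected value in this assay is 2500 nM, within a range from 800 nM to 8000 nM.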

Compound 3, half-maximal effective concentration: 1100 nM
Compound 3: the middle estimate sits 2.3-fold (0.36 log units) above what was measured; the range from low to high includes it.
By their numbers in this assay, from the lowest: compounds 3 and 1 (each within the scatter of the next); then compound 2.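

In this assay, placing 2-methoxyphenyl instead of 4-ethoxyphenyl on the carbonyl carbon gives a 1.2-fold lower number from compound 1 to compound 3 (0.09 log units; within the scatter), so this measurement cannot tell the two compounds apart. Within the data shown here, this is the first comparison in the family that differs in only one place, and it shows that this site can carry either group with no shift beyond the scatter. No outside evidence bears on this result.

A 4-methoxyphenyl or a 2-ethoxyphenyl group would be needed to separate the length of the chain from where it sits on the ring, and neither is among the compounds shown. From the compounds shown here alone, it also remains open whether a longer chain, such as 4-butoxyphenyl, or an amine on this ring would leave the number just as unchanged.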